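From Isopropyl to Isobutyl on a Ring Nitrogen

This account rests on a few compounds, and the source may have more. Where it says the series, first, only, none or still open, it means among the compounds named here.

compound 1 `CC(C)[N+]1(C)CCc2c(sc(NC(=O)Nc3ccc(Cl)cc3)c2C(N)=O)C1` gives 960 nM
compound 2 `CCN1CCc2c(sc(NC(=O)NCC3CCCO3)c2C(N)=O)C1` gives > 25000 nM (a limit of the assay, not a number)
compound 3 `NC(=O)c1c(NC(=O)Nc2ccc(Cl)cc2)sc2c1CCN(CC1CCCCC1)C2` gives 1890 nM

In a functional assay (strain AB) with Danio rerio as the target, read by microscopy, with a stated time of 1 h (a higher number here means that more compound is needed for the effect, a lower number that less compound is needed), compound 1 at 960 nM and compound 3 at 1890 nM lie within the usual scatter of each other. Compound 4 `CC(C)C[N+]1(C)CCc2c(sc(NC(=O)Nc3ccc(Cl)cc3)c2C(N)=O)C1` keeps the core of compound 1 and carries isobutyl in place of isopropyl on an amine nitrogen in a ring. Among the measured compounds shown here, no measured pair shows this change, so the expectation in this assay rests on the change alone: no step beyond the scatter, in either direction. The estimated step is a 1.1-fold higher number from compound 1 to compound 4 (0.06 log units; within the scatter) and stays within that scatter. The estimate for compound 4 is 1100 nM with an expected range of 450 nM to 2800 nM (estimated, not measured).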

Compound 4, half-maximal effective concentration: 380 nM
For compound 4 the middle estimate is 2.9-fold (0.46 log units) above the measured one; the whole stated range lies above it.
By their numbers in this assay, from the lowest: compound 4; then compounds 1 and 3 (each within the scatter of the next). At a limit, above all of these: compound 2.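

In this assay, the pair shows a 2.5-fold lower number from compound 1 to compound 4 (0.40 log units; beyond the scatter) when isobutyl replaces isopropyl on an amine nitrogen in a ring. Among the compounds shown here, this is the first comparison here between compounds that differ in one place, and it shows that this position responds to a small change in its carbon chain, with the shared core left untouched. No measurement shown explains the step.

One pair cannot show whether the trend continues with a longer chain such as pentyl, or how a chain ending in a hydroxyl group or a carboxylic acid would behave.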